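Bromo to nitro on the shared core of compound 3

A few compounds are considered here, and "the series" means these few. Any claim that something is new, unique, unknown or untested is made for them only; others in the source may bear on it.

Measured compounds:
compound 1, `Cc1ccc(-c2nnc(Nc3ncccn3)o2)cc1`: < 20%
compound 2, `COc1ccc(-c2nnc(Nc3ncccn3)o2)cc1`: 45.8%
compound 3, `Brc1ccc(-c2nnc(Nc3ncccn3)o2)cc1`: 47.8%

In a functional assay, with a stated time of 30 min, tested at 20 uM (a lower number here means less inhibition, a higher number more inhibition at the concentration tested (going by the name of the read-out)), compound 1 gives only a limit of the assay, not a number (the limit of < 20% in this assay, at which 1 of the 3 values shown sits). Compound 2 gives 45.8% and compound 3 gives 47.8%, the highest of the two numbers; the step of a number 2 percentage points higher from compound 2 to compound 3 (within the scatter) lies within the scatter. Compound 4, `O=[N+]([O-])c1ccc(-c2nnc(Nc3ncccn3)o2)cc1`, differs from compound 3 by nitro in place of bromo on an aromatic carbon. Within the data shown here, the steps of a number at least 25.8 percentage points higher from compound 1 to compound 2 (beyond the scatter) and a number at least 27.8 percentage points higher from compound 1 to compound 3 (beyond the scatter) show that a change at this position can move the read-out, but no measured step involves nitro. Compound 4 is therefore expected to show a step of a number 2.2 percentage points higher from compound 3 to compound 4 (within the scatter), none beyond the scatter. The estimate for compound 4 is 50%, between 25% and 72%.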

Compound 4, a percentage reported as inhibition, at one concentration (the size of the read-out at that concentration, not a potency): < 20%
Compound 4: a limit, no number; the forecaster's own chance of this, stated with the estimate: 15%; at least 30 percentage points between middle value and limit.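

In this assay compound 4 gives < 20%, which is a limit of the assay and not a number. Nitro in place of bromo gives a number at least 27.8 percentage points lower from compound 3 to compound 4 (beyond the scatter), and nitro in place of methoxy gives a number at least 25.8 percentage points lower from compound 2 to compound 4 (beyond the scatter), so methyl is no longer the only group at this position that falls away from bromo and methoxy. The step between the methyl and nitro compounds cannot be read: the limit of < 20% in this assay, at which 2 of the 4 values shown sit.

The compounds shown leave open how an amine or a carboxylic acid would read at this position. They also leave open whether any group here exceeds bromo and methoxy.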